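Switching the ring nitrogen out and keeping the cyclopropylcarbonyl

A few compounds are considered here, and "the series" means these few. Any claim that something is new, unique, unknown or untested is made for them only; others in the source may bear on it.

The account concerns four compounds that share a sulfonamide-bearing aryl carboxamide linked to a fused bicyclic ring, and it follows a single change at an exocyclic nitrogen across two cores. Compound 1 `COc1c(NS(=O)(=O)c2ccc(F)cc2)cc(-c2ccc3nc(NC4CC4)sc3n2)cc1C(N)=O` is measured in a functional assay on U-87MG ATCC cells (Homo sapiens) for antiproliferative activity, read by MTT assay, with a stated time of 72 h (a higher number here means a weaker inhibitor, a lower number a stronger inhibitor), where compound 1 gives 41700 nM. Compound 2 `COc1c(NS(=O)(=O)c2ccc(F)cc2)cc(-c2ccc3nc(NC(=O)C4CC4)sc3n2)cc1C(N)=O` carries cyclopropylcarbonyl in place of cyclopropyl on a nitrogen on an aromatic ring, and in this assay compound 2 gives 20500 nM. The step of a 2.0-fold lower number from compound 1 to compound 2 (0.31 log units; beyond the scatter) is therefore modest but lies beyond the usual scatter.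

Compound 3 `COc1c(NS(=O)(=O)c2ccc(F)cc2)cc(-c2ccc3nc(NC4CC4)sc3c2)cc1C(N)=O` has a different core from compound 1; the difference between the two cores is not broken down here. In this assay the entry for compound 3 reads "not determined" (no result reported), so no number is available for it. Compound 4 `COc1c(NS(=O)(=O)c2ccc(F)cc2)cc(-c2ccc3nc(NC(=O)C4CC4)sc3c2)cc1C(N)=O` is related to compound 3 by cyclopropylcarbonyl in place of cyclopropyl on a nitrogen on an aromatic ring. The place of this change reads the same, word for word, as the place of the change from compound 1 to compound 2, so it counts as the same change made on a second core; it occurs twice among the four compounds.

Within the data shown here, because the only measured instance of the change is a 2.0-fold lower number from compound 1 to compound 2 (0.31 log units; beyond the scatter), the same modest step is expected from compound 3 to compound 4 in this assay, though no number for compound 3 anchors it, and the expectation for compound 4 rests mainly on compound 2 and its value 20500 nM. On that basis compound 4 is estimated at 20000 nM, expected to fall between 5000 nM and 80000 nM.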

Compound 4, half-maximal inhibitory concentration: 2870 nM
Estimate against measurement, compound 4: 7.0-fold (0.84 log units) above; measured number outside the range, below it.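

In this assay, among these compounds, compound 4 gives 2870 nM, but compound 3 has no number there, so no step from compound 3 to compound 4 can be read. The compounds shown leave open whether the change from cyclopropylamino to (cyclopropylcarbonyl)amino moves the number on this second core as it does on the core of compound 1. Nothing shown here offers an explanation for the value of compound 4.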